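Compound 2 to compound 3: phenyl to 2-chlorophenyl

A few compounds are considered here, and "the series" means these few. Any claim that something is new, unique, unknown or untested is made for them only; others in the source may bear on it.

Compound 1 `CN1CCC(n2cc(S(=O)(=O)c3ccccc3)c3cccnc32)C1` and compound 2 `O=S(=O)(c1ccccc1)c1cn(C2CCCNC2)c2ncccc12` share one core. In a functional assay on HeLa cells for agonist activity at 5-hydroxytryptamine receptor 6 (Homo sapiens), read by cAMP accumulation and immunoassay (a lower number here means a smaller maximal response, a higher number a larger maximal response), compound 1 gives 61%, and compound 2 gives 56%. Going by the values given here, the only measured step, a number 5 percentage points lower from compound 1 to compound 2 (within the scatter), is within the scatter, so compound 2 holds the lowest of the two numbers without being separable from compound 1.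

Compound 3 `O=S(=O)(c1ccccc1Cl)c1cn(C2CCCNC2)c2ncccc12` differs from compound 2 by chloro in place of hydrogen on an aromatic carbon. Among the compounds with values here, no measured step concerns a change of this kind; the single step available alters the group on the aromatic nitrogen and leaves the phenyl untouched, so it offers no precedent. With nothing to go on beyond the two values, no step beyond the scatter is expected in this assay. For compound 3 the expected value is 56%, with a range from 40% to 72%. The expected step of no change at the digits printed from compound 2 to compound 3 (within the scatter) is therefore taken as small.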

Compound 3, largest response reached (Emax), in percent of the reference or control that the assay uses: 84%
Beside the measured number, compound 3's estimate is 28 percentage points below it; measured number outside the range, above it.
By their numbers in this assay, from the lowest: compounds 2 and 1 (each within the scatter of the next); then compound 3.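

Going by these compounds alone, this is the first change to move the number beyond the scatter: in this assay, chloro in place of hydrogen, ortho to a large group on the phenyl, gives a number 28 percentage points higher from compound 2 to compound 3 (beyond the scatter). The earlier step, a number 5 percentage points lower from compound 1 to compound 2 (within the scatter), concerned only the group on the aromatic nitrogen, so it said nothing about the phenyl; that ring now proves to be a place where a change can alter the maximal response. Nothing on hand accounts for this rise.

Still open, as far as these compounds go, is whether fluoro, methyl or methoxy at the same place, or chloro at another carbon of that ring, would give a step of like size. Also open, from the compounds shown here alone, is whether the 2-chlorophenyl would have the same effect with 1-methylpyrrolidin-3-yl on the aromatic nitrogen.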